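From 2-hydroxyphenyl to 3-hydroxyphenyl: a step without a starting number

A few compounds are considered here, and "the series" means these few. Any claim that something is new, unique, unknown or untested is made for them only; others in the source may bear on it.

Three compounds have so far been examined in a functional assay on RAW264.7 cells (Mus musculus) for inhibition, read by fluorescence, with stated times of 1 h, 24 h and 30 min (on this read-out lower numbers stand for stronger inhibition and higher numbers for weaker inhibition), and none of them has yielded a measured potency. Compound 1 (`O=C(/C=C/c1ccccc1C(F)(F)F)c1cccc(O)c1`) gives > 10000 nM as a limit of the assay and not a number. Compound 2 (`O=C(/C=C/c1ccccc1OC(F)(F)F)c1ccccc1`) gives > 10000 nM as a limit of the assay and not a number either. Compound 3 (`O=C(/C=C/c1ccccc1OC(F)(F)F)c1ccccc1O`) has the entry "not determined" (no result reported) and so holds no place on the scale. Among the compounds with values here, the only values around it are those two limits.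

Still to be measured is compound 4 (`O=C(/C=C/c1ccccc1OC(F)(F)F)c1cccc(O)c1`). The change 3-hydroxyphenyl in place of 2-hydroxyphenyl on a carbonyl carbon puts 3-hydroxyphenyl in place of 2-hydroxyphenyl on a carbonyl carbon. Within the data shown here, no measured step gives a size for this change, and without a number for compound 3 none can be read from the data. In this assay the expectation is therefore no step beyond the usual scatter, in neither direction, with the result staying at the weak end. This expectation for compound 4 rests on compound 1 at > 10000 nM as a limit, and nothing closer is known. Compound 4 is expected at about 10000 nM with an estimated range from 3000 nM to 30000 nM. A limit of the assay instead of a number is also a likely outcome for compound 4.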

Compound 4, half-maximal inhibitory concentration: 1610 nM
Compound 4: the middle estimate sits 6.2-fold (0.79 log units) above what was measured, outside the stated range (below it).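

In this assay, compound 4 is the first of the compounds shown to give a number instead of a limit of the assay, so a measurable result is possible on this core when 3-hydroxyphenyl sits on the carbonyl carbon and the trifluoromethoxy group is kept. Both single changes that lead to it count: hydroxy in place of hydrogen on an aromatic carbon gives an at least 6.2-fold lower number from compound 2 to compound 4 (0.79 log units; beyond the scatter), and trifluoromethoxy in place of trifluoromethyl on an aromatic carbon gives an at least 6.2-fold lower number from compound 1 to compound 4 (0.79 log units; beyond the scatter). Neither step has a full size, only a minimum, because each starts from a limit: the limit of > 10000 nM in this assay, at which 2 of the 4 values shown sit.

The step from 2-hydroxyphenyl to 3-hydroxyphenyl, the change in question, still cannot be read, since compound 3 has no result, so the data do not say whether moving the hydroxy matters or whether any hydroxyphenyl would do. Also open, as far as these compounds go, is whether an amine or a carboxylic acid in place of the hydroxy on the 3-hydroxyphenyl group would keep a measurable result in this assay.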